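This account rests on a few compounds, and the source may have more. Where it says the series, first, only, none or still open, it means among the compounds named here.

Measured compounds:
- Compound 1, `COc1ccccc1Nc1nc(-c2ccc(F)cc2)c(CC(=O)O)s1`: in an in vitro functional assay on HEK285-7 cells for antagonist activity at prostaglandin D2 receptor 2 (Homo sapiens), read by BRET and beta-arrestin recruitment (a higher number here means a weaker inhibitor, a lower number a stronger inhibitor), compound 1 gives 2100 nM.
- Compound 2, `COc1ccccc1Nc1nc(-c2ccc(Cl)cc2)c(CC(=O)O)s1`: in this assay compound 2 gives 730 nM.
- Compound 3, `O=C(O)Cc1sc(Cc2ccccc2)nc1-c1ccc(Cl)cc1`: in this assay compound 3 gives 4100 nM.

Compound 4, `O=C(O)Cc1sc(Cc2ccccc2)nc1-c1ccc(F)cc1`, has not yet been measured.

Compounds 1 and 2 share one core and differ in a single place: fluoro in place of chloro on an aromatic carbon. That change made a step of a 2.9-fold higher number from compound 2 to compound 1 (0.46 log units; beyond the scatter), so the fluoro compound came out as the weaker inhibitor of the pair.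

Compound 3 carries a different core from compound 2; the difference between the two cores is not broken down here, and only their two values can be set side by side, which show compound 3 at the higher number of the two.

Compound 4 is built from compound 3 by the very same change: fluoro in place of chloro on an aromatic carbon. The place is described in the same words in both pairs, so this is the same change, made on a second core.

Among the measured compounds shown here, with only one earlier example of this change, the expectation for compound 4 rests on that single step. The step from compound 3 to compound 4 is expected to be a 2.4-fold higher number from compound 3 to compound 4 (0.39 log units; beyond the scatter), because compound 2 to compound 1 showed a 2.9-fold higher number from compound 2 to compound 1 (0.46 log units; beyond the scatter). On that basis compound 4 is estimated to give about 10000 nM in this assay, most likely between 4000 nM and 30000 nM.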

Compound 4, half-maximal inhibitory concentration: 180 nM
Compound 4: the middle estimate sits 56-fold (1.74 log units) above what was measured; the whole stated range lies above it.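

In this assay, replacing 4-chlorophenyl with 4-fluorophenyl on the core of compound 3 gave a 23-fold lower number from compound 3 to compound 4 (1.36 log units; beyond the scatter), which makes the fluoro compound the stronger inhibitor of this pair, whereas it was the weaker one on the core of compound 1. The same small swap therefore did not carry over from one core to the other, differing in both direction and size: the same change on two cores in this assay, a 2.9-fold higher number (0.46 log units; beyond the scatter) from compound 2 to compound 1 and a 23-fold lower number (1.36 log units; beyond the scatter) from compound 3 to compound 4, 66-fold (1.82 log units) apart, beyond the scatter of two such steps. Among the compounds shown here, this shows that, for these two pairs, the effect of the swap depends on the core it is made on, but with only one pair per core it does not show which feature of the cores is responsible, why the direction reverses, or what the swap would do on any other core.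

Going by these compounds, it remains open whether a bromo or methyl group in the same place would follow the trend of compound 3 and compound 4 or that of compound 1 and compound 2. On these data alone, it is also open whether the stronger result with fluoro on the core of compound 3 would persist if an amide or a longer chain replaced the benzyl group of that core.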